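The compounds below may be only part of what the source reports. "The series", "measured", "known", "first", "only" and "open" are said of these compounds alone.

Measured so far in a functional assay on A549 cells (Homo sapiens) for antiproliferative activity, read by MTT assay, with a stated time of 72 h; a lower number here means a stronger inhibitor, a higher number a weaker inhibitor:
compound 1 `COc1cc(-n2cnc3ccc(-c4ccc(C(F)(F)F)cc4)cc32)cc(OC)c1OC`, 3390 nM;
compound 2 `COc1cccc(-c2ccc3ncn(-c4cc(OC)c(OC)c(OC)c4)c3c2)c1`, 3180 nM;
compound 3 `COc1cc(-n2cnc3ccc(-c4ccccc4)cc32)cc(OC)c1OC`, 3060 nM.

Compound 1 gives the highest of these three numbers, but that says little: the step of a 1.1-fold lower number from compound 1 to compound 2 (0.03 log units; within the scatter) and the step of a 1.1-fold lower number from compound 1 to compound 3 (0.04 log units; within the scatter) both lie within the scatter, as does a 1.0-fold lower number from compound 2 to compound 3 (0.02 log units; within the scatter). The three compounds share one core and differ only in the group placed on an aromatic carbon of it, and no such exchange has yet shifted this assay.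

Compound 4 `COc1ccc(-c2ccc3ncn(-c4cc(OC)c(OC)c(OC)c4)c3c2)cc1O` is not yet measured. It differs from compound 1 by 3-hydroxy-4-methoxyphenyl in place of 4-(trifluoromethyl)phenyl on an aromatic carbon. The steps bearing on this are the exchanges of that same group: a 1.1-fold lower number from compound 1 to compound 2 (0.03 log units; within the scatter), a 1.1-fold lower number from compound 1 to compound 3 (0.04 log units; within the scatter) and a 1.0-fold lower number from compound 2 to compound 3 (0.02 log units; within the scatter), each within the scatter. Another exchange at the same place is therefore expected to give no step beyond the scatter, a 1.0-fold lower number from compound 1 to compound 4 (0.01 log units; within the scatter). Compound 4 is expected to give 3300 nM, in the range 1500 nM to 7500 nM.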

Compound 4, half-maximal inhibitory concentration: 200 nM
The estimate for compound 4 lay 17-fold (1.22 log units) above the measured number; the measured number lies below the stated range.
By their numbers in this assay, from the lowest: compound 4; then compounds 3, 2 and 1 (each within the scatter of the next).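

The position on the shared core that had given only steps within the scatter in this assay does respond to its substituent: 3-hydroxy-4-methoxyphenyl gives a 17-fold lower number from compound 1 to compound 4 (1.23 log units; beyond the scatter) and a 15-fold lower number from compound 3 to compound 4 (1.18 log units; beyond the scatter) as well as a 16-fold lower number from compound 2 to compound 4 (1.20 log units; beyond the scatter) in this series. The last step shows that a methoxy group on the phenyl ring, as in compound 2, does not by itself reproduce the result of compound 4. Nothing available here explains these steps. The compounds shown leave open whether a phenyl ring bearing the hydroxy group alone would match compound 4. They also leave open whether an amine or a carboxylic acid in place of that hydroxy group would.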